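The compounds below may be only part of what the source reports. "The series", "measured", "known", "first", "only" and "open" are said of these compounds alone.

Measured compounds, cytotoxicity in a functional assay on MDA-MB-231 cells (Homo sapiens) for cytotoxicity, read by MTT assay, with a stated time of 72 h; on this read-out higher numbers stand for weaker inhibition and lower numbers for stronger inhibition:

- compound 1 `CN(C)CCCNc1nc(-c2ccc(NC(=O)Nc3ccccc3F)cc2)nc2ccsc12`: 660 nM
- compound 2 `Cc1ccc(NC(=O)Nc2ccc(-c3nc(NCCN(C)C)c4sccc4n3)cc2)cc1`: 2180 nM
- compound 3 `CCN(CC)CCCNc1nc(-c2ccc(NC(=O)Nc3ccccc3)cc2)nc2c(Cl)c(Cl)sc12`: 1780 nM

Compound 3 stands second highest of the three numbers in this assay . Its nearest neighbour is compound 2, whose number lies within the scatter of that of compound 3; compound 1, with the lowest number, sits beyond the scatter from compound 3. Compound 2 and compound 3 differ in more than one place, so their values say nothing about any single change.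

Compound 4 `CCN(CC)CCCNc1nc(-c2ccc(NC(=O)Nc3ccc(C)cc3)cc2)nc2c(Cl)c(Cl)sc12` is not yet measured. It differs from compound 3 by methyl in place of hydrogen on an aromatic carbon. Going by the values given here, no measured pair carries this change on its own. The nearest comparison, compound 2 bearing the 4-methylphenyl urea against compound 1 bearing a 2-fluorophenyl urea, is confounded by the other differences between them. The step of a 1.1-fold higher number from compound 3 to compound 4 (0.05 log units; within the scatter) is expected to be small, with no direction beyond the scatter. Compound 4 is therefore estimated at 2000 nM, within 900 nM to 4500 nM.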

Compound 4, half-maximal inhibitory concentration: 3040 nM
The estimate for compound 4 lay 1.5-fold (0.18 log units) below the measured number; the range from low to high includes it.
By their numbers in this assay, from the lowest: compound 1; then compounds 3, 2 and 4 (each within the scatter of the next).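

In this assay the change from phenylcarbamoyl to (4-methylphenyl)carbamoyl gives the series its first step that can be read in one place: a 1.7-fold higher number from compound 3 to compound 4 (0.23 log units; within the scatter). On this aromatic carbon, para to a large group, a single added methyl therefore leaves the number inside the usual scatter, so this pair shows no effect of the change that can be told apart from repeat variation. No measurement at hand bears on an explanation for this result.

From the compounds shown here alone, whether another group on the same carbon, such as methoxy, chlorine or a carboxylic acid, would take the number beyond the scatter stays open. Also open, going by these compounds, is whether the methyl step would read the same on the core and side chain of compound 1, since this single pair covers only one setting.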